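Moving the Chlorine: From Compound 3 to Compound 4

The compounds below may be only part of what the source reports. "The series", "measured", "known", "first", "only" and "open" are said of these compounds alone.

Measured compounds:
- compound 1 `NC1=NC2(CCSCC2)N(OCCCOc2ccc(Cl)c(Cl)c2)C(N)=N1` gives 89.8% in an assay on isolated protein for inhibition of Dihydrofolate reductase (Homo sapiens), read by spectrophotometry, using NADPH, with stated times of 5 s and 6 min, tested at 50 uM; on this read-out lower numbers stand for a weaker effect and higher numbers for a stronger effect at the one concentration tested
- compound 2 `NC1=NC2(CCSCC2)N(OCCCOc2cccc(Cl)c2)C(N)=N1` gives 88.8% in this assay
- compound 3 `NC1=NC2(CCOCC2)N(OCCCOc2ccc(Cl)cc2)C(N)=N1` gives "not determined" (no result reported) in this assay, that is, no result reported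

Compound 3 therefore stands nowhere on the numbers: its read-out in this assay was not determined, so there is no starting value from which the step to compound 4 could be counted. Compound 4 `NC1=NC2(CCOCC2)N(OCCCOc2cccc(Cl)c2)C(N)=N1` differs from compound 3 only in the aryl ring: 3-chlorophenyl in place of 4-chlorophenyl on an oxygen on a saturated carbon

Among the compounds with values here, no measured pair shows exactly this change. Within the data shown here, the only measured step, a number 1 percentage points lower from compound 1 to compound 2 (within the scatter), concerns a chlorine on the same kind of aryl ring but in compounds whose core holds sulfur in place of the oxygen of compounds 3 and 4. That step was within the scatter, so the two chlorine patterns tested so far gave read-outs that cannot be told apart. By that loose comparison, no step beyond the scatter is expected from compound 3 to compound 4 in this assay, and compound 4 is expected to sit in the same high region as compounds 1 and 2, with a wider range because the core differs and compound 3 itself is unmeasured. Compound 4 is estimated at 86%, between 65% and 96%.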

Compound 4, a percentage reported as inhibition, at one concentration (the size of the read-out at that concentration, not a potency): 85.8%
For compound 4 the middle estimate is 0.2 percentage points above the measured one, and the stated range covers the measured number.
By their numbers in this assay, from the lowest: compounds 4, 2 and 1 (each within the scatter of the next).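

Within the data shown here, compound 3 has the entry "not determined" (no result reported) in this assay while compound 4 gives 85.8% so no step from one to the other can be read. No further data here offer an explanation for the value of compound 4. As far as these compounds go, whether 3-chlorophenyl in place of 4-chlorophenyl shifts the read-out on this shared core remains open.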